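Changing the benzoyl ring on a compound at the assay limit

The source may hold more compounds than are shown below. What is called first, only, known or untested is meant among the compounds shown, and "the series" means these compounds.

Compound 1, `CN(C(=O)NC(=O)c1ccc(Cl)cc1Cl)c1nc(C(F)(F)F)c(C(=O)N/N=C/c2cccc(C(F)(F)F)c2)s1`, gives 10.6 ug/mL in a functional assay on A549 cells (Homo sapiens) for inhibition, read by MTT assay, with a stated time of 72 h; on this read-out higher numbers stand for weaker inhibition and lower numbers for stronger inhibition.
Compound 2, `CN(C(=O)NC(=O)c1ccc(Cl)cc1Cl)c1nc(C(F)(F)F)c(C(=O)N/N=C/c2cc(C(F)(F)F)cc(C(F)(F)F)c2)s1`, returns only the limit > 100 ug/mL in this assay.

Among the compounds with values here, the one measured step, an at least 9.4-fold higher number from compound 1 to compound 2 (0.97 log units; beyond the scatter), puts a trifluoromethyl in place of a hydrogen on the aromatic ring attached to the hydrazone and moves the number from a measured value to the assay limit (the limit of > 100 ug/mL in this assay, at which 1 of the 2 values shown sits). Compound 2 therefore stands only as a limit, and its true value is not known. Compound 3, `CN(C(=O)NC(=O)c1c(F)cccc1F)c1nc(C(F)(F)F)c(C(=O)N/N=C/c2cc(C(F)(F)F)cc(C(F)(F)F)c2)s1`, keeps every part of compound 2 except one: 2,6-difluorophenyl in place of 2,4-dichlorophenyl on a carbonyl carbon. Within the data shown here, no measured step touches the ring on this carbonyl carbon, so the data give no direction for the change, and the starting point is itself a limit rather than a number. The step from compound 2 to compound 3 is estimated as a number no higher from compound 2 to compound 3 (the limit leaves the size open), that is, none that can be resolved. Compound 3 is therefore expected to remain close to the limit, with an estimate of 100 ug/mL and a range from 25 ug/mL to 300 ug/mL, most likely reported again only as a limit.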

Compound 3, half-maximal inhibitory concentration: 17.3 ug/mL
Beside the measured number, compound 3's estimate is 5.8-fold (0.76 log units) above it, and the stated range ends above it.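

In this assay, the ring on the carbonyl carbon proves able to move the read-out: 2,6-difluorophenyl in place of 2,4-dichlorophenyl gives an at least 5.7-fold lower number from compound 2 to compound 3 (0.76 log units; beyond the scatter), which brings the bis(trifluoromethyl) hydrazone series back from the limit to a measured value. The earlier compounds shown here showed only a change on the aromatic ring attached to the hydrazone, and that step went towards weaker inhibition, whereas this second position moves the number the other way for this one pair. The starting point of the step is a limit and not a number, so its true size stays open: the limit of > 100 ug/mL in this assay, at which 1 of the 3 values shown sits.

The compounds shown leave open whether the same exchange would act alike on the hydrazone ring of compound 1, and compound 1 and compound 3 differ in two places, so they offer no direct comparison. They also leave open whether the step follows the kind of halogen or where it sits on the ring, and how a methoxy group or an amine on this ring would read.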